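The source may hold more compounds than are shown below. What is called first, only, known or untested is meant among the compounds shown, and "the series" means these compounds.

Working notes on the series. In a functional assay on DU-145 cells (Homo sapiens) for inhibition, read by trypan blue exclusion, with a stated time of 96 h (a higher number here means a weaker inhibitor of growth, a lower number a stronger inhibitor of growth), compound 1 (`O=C(/C(=C\c1c(O)cc(O)cc1O)S(=O)(=O)c1ccccc1Br)c1ccc(Br)cc1`) gives 50000 nM and compound 2 (`O=C(O)c1ccc(C(=O)/C(=C\c2ccc(O)c([N+](=O)[O-])c2)SCc2ccc(Br)cc2)cc1`) gives 50000 nM. Compound 3 (`COc1cc(/C=C(/SCc2ccc(Br)cc2)C(=O)c2ccc(C(=O)O)cc2)ccc1F`) gives 1000 nM, the lowest of the three numbers.

The next compound is compound 4 (`CN(C)c1ccc(/C=C(/SCc2ccc(Br)cc2)C(=O)c2ccc(C(=O)O)cc2)cc1`). The change is 4-(dimethylamino)phenyl in place of 4-fluoro-3-methoxyphenyl on a double-bonded chain carbon bound to a double-bonded chain carbon.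

Among the measured compounds shown here, one measured step bears on this place: a 50-fold lower number from compound 2 to compound 3 (1.70 log units; beyond the scatter). It is large and beyond the scatter, so the group here can move the number strongly in this assay. For the measured compounds named here, that single step gives no rule for 4-(dimethylamino)phenyl, which no measured compound carries. Compound 3 already holds the lowest number of the set, so a move to a higher number is expected, though of moderate size and well short of the measured step.

The expected step is a 3.0-fold higher number from compound 3 to compound 4 (0.48 log units; beyond the scatter). For compound 4 the estimated value is 3000 nM, with an expected range of 500 nM to 30000 nM.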

Compound 4, concentration for 50% growth inhibition: 50000 nM
For compound 4 the middle estimate is 17-fold (1.22 log units) below the measured one, outside the stated range (above it).
By their numbers in this assay, from the lowest: compound 3; then compounds 1, 2 and 4 (each within the scatter of the next).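

In this assay the move to 4-(dimethylamino)phenyl gives a 50-fold higher number from compound 3 to compound 4 (1.70 log units; beyond the scatter) and shows that the low number at this place is not shared by every replacement group. Set against 4-hydroxy-3-nitrophenyl, the same group gives no change at the digits printed from compound 2 to compound 4 (within the scatter) and the two cannot be told apart, leaving 4-fluoro-3-methoxyphenyl as the only one of the three groups at this place with the lower number. Nothing at hand accounts for this difference between the groups.

From the compounds shown here alone, whether the fluorine, the methoxy or the two together carry the lower number remains open, and 4-fluorophenyl and 3-methoxyphenyl at this place would separate them. Also open, going by these compounds, is whether the 4-fluoro-3-methoxyphenyl result holds when the carboxylic acid of the shared core gives way to an amide.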